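A few compounds are considered here, and "the series" means these few. Any claim that something is new, unique, unknown or untested is made for them only; others in the source may bear on it.

Three analogues built on one shared core have been examined in a functional assay for inhibition of sodium/hydrogen exchanger (Oryctolagus cuniculus); on this read-out lower numbers stand for stronger inhibition and higher numbers for weaker inhibition. Compound 1 `Cc1cc(F)c(S(C)(=O)=O)cc1C(=O)N=C(N)N` gives 44 nM, compound 2 `Cc1cc(Cl)c(S(C)(=O)=O)cc1C(=O)N=C(N)N` gives 25 nM, and compound 3 `Cc1cc(-c2ccc(Cl)cc2Cl)c(S(C)(=O)=O)cc1C(=O)N=C(N)N` gives 42 nM. Compound 2 shows the lowest of these three numbers, yet both neighbouring steps are within the scatter, so no ranking can be claimed. Compound 4 `Cc1cc(SC(C)C)c(S(C)(=O)=O)cc1C(=O)N=C(N)N` differs from compound 2 in one place: isopropylsulfanyl in place of chloro on an aromatic carbon. Earlier exchanges at this same aromatic carbon bear on it: a 1.8-fold lower number from compound 1 to compound 2 (0.25 log units; within the scatter), a 1.7-fold higher number from compound 2 to compound 3 (0.23 log units; within the scatter) and a 1.0-fold lower number from compound 1 to compound 3 (0.02 log units; within the scatter) all stayed within the scatter, even when a group of many atoms entered. A step no larger than the scatter is therefore expected in this assay, a 1.2-fold higher number from compound 2 to compound 4 (0.08 log units; within the scatter). Compound 4 is estimated at 30 nM, with a range from 12 nM to 80 nM.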

Compound 4, half-maximal inhibitory concentration: 12 nM
Estimate against measurement, compound 4: 2.5-fold (0.40 log units) above; measured number inside the range.
By their numbers in this assay, from the lowest: compound 4; then compounds 2, 3 and 1 (each within the scatter of the next).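

Going by these compounds alone, this aromatic carbon had so far given only steps within the scatter, but isopropylsulfanyl in place of chloro gives a 2.1-fold lower number from compound 2 to compound 4 (0.32 log units; beyond the scatter). Against the other two groups the change is also beyond the scatter, with a 3.5-fold lower number from compound 3 to compound 4 (0.54 log units; beyond the scatter) and a 3.7-fold lower number from compound 1 to compound 4 (0.56 log units; beyond the scatter), so compound 4 stands apart from the other three, though all three steps are modest. No available evidence bears on the reason for this difference.

The compounds shown leave open whether the sulfur or the branched isopropyl chain matters more. An isopropoxy group or a plain isopropyl group on this carbon would help separate the two.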